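Working notes: from compound 2 to compound 4

The source may hold more compounds than are shown below. What is called first, only, known or untested is meant among the compounds shown, and "the series" means these compounds.

All values below come from an assay on HEK-293T cells for antagonist activity at vitamin D3 receptor (Homo sapiens), read by a luciferase reporter, with a stated time of 24 h; a lower number here means a stronger inhibitor, a higher number a weaker inhibitor.

- compound 1 `CC(C)c1onc(-c2c(Cl)cccc2Cl)c1COc1ccc(-c2nc3cc(C(=O)O)ccc3n2C)cc1`: 4410 nM
- compound 2 `CC(C)c1onc(-c2c(Cl)cccc2Cl)c1COc1ccc(-c2nc3ccc(C(=O)O)cc3n2CC(C)(C)C)cc1`: 861 nM
- compound 3 `CCC(CC)n1c(-c2ccc(OCc3c(-c4c(Cl)cccc4Cl)noc3C(C)C)cc2F)nc2ccc(C(=O)O)cc21`: only a limit, see below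

Of the two numbers shown, compound 2 stands at the lower one; compound 1 sits higher by a margin beyond the usual scatter of repeated measurements. For compound 3 this assay reports no number but a limit, > 10000 nM. That reading is the limit of > 10000 nM in this assay, at which 1 of the 3 values shown sits, so the position of compound 3 relative to the other two cannot be placed more closely.

Within the data shown here, no step between two measured compounds that differ in a single place is available, so the change to compound 4 `CC(=O)C1CCC(Cn2c(-c3ccc(OCc4c(-c5c(Cl)cccc5Cl)noc4C(C)C)cc3)nc3ccc(C(=O)O)cc32)CC1` has to be judged on the structures alone. The difference is 4-acetylcyclohexyl in place of tert-butyl on a saturated chain carbon bound to an aromatic nitrogen. A tert-butyl group leaves and a 4-acetylcyclohexyl group enters on the saturated chain carbon bound to the aromatic nitrogen; cut one bond further out, neopentyl becomes (4-acetylcyclohexyl)methyl.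

With nothing measured on this kind of change, the expectation in this assay is a small shift, if any, and not one that clearly exceeds the scatter in either direction. Compound 4 is expected to give 600 nM, with a plausible range from 150 nM to 3000 nM. The estimated step of a 1.4-fold lower number from compound 2 to compound 4 (0.16 log units; within the scatter) is therefore a modest one.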

Compound 4, half-maximal inhibitory concentration: > 10000 nM
Compound 4 ended at the assay's limit; the forecaster's own chance of this, stated with the estimate: 10%; middle value at least 16-fold (1.22 log units) away from the limit.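

Among these compounds, compound 4 gives the first reading of a single-place change at this position. In this assay the move from tert-butyl to 4-acetylcyclohexyl on the saturated chain carbon bound to the aromatic nitrogen gives an at least 11-fold higher number from compound 2 to compound 4 (1.06 log units; beyond the scatter) and is a large loss, so this position does not tolerate every larger group in place of the tert-butyl of neopentyl. The step can be sized no further because the reading of compound 4 is a limit and not a number: the limit of > 10000 nM in this assay, at which 2 of the 4 values shown sit.

The change brings in the six-membered ring of carbon and the acetyl carbonyl together, so the compounds shown do not tell which of the two goes with the loss; a plain cyclohexyl, or a hydroxyl in place of the acetyl, would pull them apart. Among the compounds shown here, also open is how the position responds to groups of other kinds on the same chain carbon, such as an amine or a longer open chain, since the one step here covers only the pair of neopentyl and (4-acetylcyclohexyl)methyl.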